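The compounds below may be only part of what the source reports. "The series", "measured", "known", "first", "only" and "open" are said of these compounds alone.

Measured in a functional assay on EBC-1 cells (Homo sapiens) for antiproliferative activity, with a stated time of 72 h; a lower number here means a stronger inhibitor, a higher number a weaker inhibitor:
- compound 1 `CNC(=O)c1cc(-c2cc(F)c3ncc(Cc4ccc5ncccc5c4)n3c2)ccc1Cl`: 946 nM
- compound 2 `O=C(c1ccc(-c2cc(F)c3ncc(Cc4ccc5ncccc5c4)n3c2)cc1F)N1CCC2(COC2)C1`: 406 nM

Of these two, compound 2 holds the lower number, at 406 nM, and its gap to compound 1 lies beyond the usual scatter. Compound 3 `CN(C)CCNC(=O)c1ccc(-c2cc(F)c3ncc(Cc4ccc5ncccc5c4)n3c2)cc1F` has not yet been measured in this assay. It differs from compound 2 on a carbonyl carbon: a group of 6 heavy atoms (4 carbon, 2 nitrogen; no ring) in place of a group of 8 heavy atoms (6 carbon, 1 nitrogen, 1 oxygen; one four-membered non-aromatic ring with 1 hetero atom, one five-membered non-aromatic ring with 1 hetero atom), on a carbonyl carbon. Going by the values given here, no measured pair of compounds shows this change. No step beyond the scatter is therefore expected, only a slight lean toward a lower number, estimated as a 1.5-fold lower number from compound 2 to compound 3 (0.16 log units; within the scatter). The expected value for compound 3 is 280 nM, with an estimated range of 80 nM to 950 nM.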

Compound 3, half-maximal inhibitory concentration: 49 nM
For compound 3 the middle estimate is 5.7-fold (0.76 log units) above the measured one; the measured number lies below the stated range.
By their numbers in this assay, from the lowest: compound 3; then compound 2; then compound 1.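

In this assay, the group on the carbonyl carbon proves to be a strong lever on the number: (2-(dimethylamino)ethyl)amino in place of the two-ring group gives a clear change (an 8.3-fold lower number from compound 2 to compound 3 (0.92 log units; beyond the scatter)). Compound 1 and compound 2 differ in more than one place, so they could not isolate this position. Nothing measured here accounts for the size of this step. From the compounds shown here alone, it remains open whether a longer chain, a diethylamino end or a carboxylic acid end would keep this level, and whether the chain's amide hydrogen or its terminal amine carries the change.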